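From Nitro to Chloro: Expected Permeability of Compound 3

The source may report more compounds than this note shows. Statements on the series, on what has been measured and on what is new or still open speak of the compounds shown alone.

Compound 1, `Cc1cc(NC(=O)Nc2cccc([N+](=O)[O-])c2)c2ccccc2n1`: 42 10^-6 cm/s
Compound 2, `Cc1cc(NC(=O)Nc2cnc3ccccc3c2)c2ccccc2n1`: 46 10^-6 cm/s

Of the compounds shown here, two have so far been measured in an ADME assay for permeability, using PAMPA, at pH 7.4; a lower number here means that the compound crosses the layer more slowly, a higher number that the compound crosses the layer faster. Compound 1 gives 42 10^-6 cm/s, and compound 2 gives 46 10^-6 cm/s. Compound 1 stands at one end of this pair of numbers, but compound 2 sits so close that the gap lies within the scatter, and the two cannot be told apart in this assay.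

Compound 3, `Cc1cc(NC(=O)Nc2cccc(Cl)c2)c2ccccc2n1`, has not yet been measured. It differs from compound 1 in one place: chloro in place of nitro on an aromatic carbon. Among the measured compounds shown here, no pair of measured compounds shows a step of this kind, so there is no measured precedent to lean on. The step in this assay is expected to be small, pointing upward if anywhere, and not clearly beyond the scatter. The estimated step is a 1.3-fold higher number from compound 1 to compound 3 (0.12 log units; within the scatter). Compound 3 is therefore expected to give about 55 10^-6 cm/s, with a likely range from 30 10^-6 cm/s to 100 10^-6 cm/s.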

Compound 3, apparent permeability: 566 10^-6 cm/s
Compound 3: the middle estimate sits 10-fold (1.01 log units) below what was measured; the whole stated range lies below it.
By their numbers in this assay, from the lowest: compounds 1 and 2 (each within the scatter of the next); then compound 3.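

In this assay, this position on the six-membered aromatic ring of carbon only, meta to a large group, turns out to be one where a single replacement can move the number by a wide margin: chloro in place of nitro gives a 13-fold higher number from compound 1 to compound 3 (1.13 log units; beyond the scatter) on an otherwise unchanged core. The change takes away the nitro group with its hydrogen-bond acceptors and its double bond and brings in a single chlorine atom, but one step cannot show which of these differences matters. Nothing available here accounts for the size of this step.

The compounds shown leave open whether another group at this position, such as fluoro, methyl or an amine, would give a number closer to that of compound 1 or that of compound 3. They also leave open whether the same replacement elsewhere on this ring would give a step of similar size.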